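Phenyl for ethyl on the saturated ring carbon of compound 2

This account rests on a few compounds, and the source may have more. Where it says the series, first, only, none or still open, it means among the compounds named here.

Of the compounds shown here, three sharing one core have been measured in an assay on Sf9 cells for inhibition of serine/threonine-protein kinase 4 (Homo sapiens), read by luminescence and ADP-Glo, with a stated time of 1 h, in the presence of a further agent that is not named here; on this read-out lower numbers stand for stronger inhibition and higher numbers for weaker inhibition. Compound 1 `CN1CC(=O)N(C)c2cnc(Nc3ccc(S(N)(=O)=O)cc3)nc21` gives 495 nM, compound 2 `CCC1C(=O)N(C)c2cnc(Nc3ccc(S(N)(=O)=O)cc3)nc2N1C` gives 479 nM, and compound 3 `CN1C(=O)C(CC2CC2)N(C)c2nc(Nc3ccc(S(N)(=O)=O)cc3)ncc21` gives 211 nM. Compound 2 therefore stands second highest of the three numbers; its nearest neighbour is compound 1, and the two lie within the scatter of each other, while compound 3 is the furthest from it, as the step of a 2.3-fold lower number from compound 2 to compound 3 (0.36 log units; beyond the scatter) shows.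

Compound 4 `CN1C(=O)C(c2ccccc2)N(C)c2nc(Nc3ccc(S(N)(=O)=O)cc3)ncc21` is not yet measured. It differs from compound 2 in one place: phenyl in place of ethyl on a saturated ring carbon.

Two measured steps speak to this change. The step of a 1.0-fold lower number from compound 1 to compound 2 (0.01 log units; within the scatter) shows that putting ethyl on this saturated ring carbon left the number where it was. The steps of a 2.3-fold lower number from compound 1 to compound 3 (0.37 log units; beyond the scatter) and a 2.3-fold lower number from compound 2 to compound 3 (0.36 log units; beyond the scatter) show that a larger group at the same carbon brought a modest lowering. Phenyl is again a larger group than ethyl, so a modest lowering of the number in this assay is expected, though the step could also stay within the scatter.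

The estimated step is a 1.8-fold lower number from compound 2 to compound 4 (0.27 log units; within the scatter). Compound 4 is expected to give 260 nM, with a range from 110 nM to 650 nM.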

Compound 4, half-maximal inhibitory concentration: 383 nM
Beside the measured number, compound 4's estimate is 1.5-fold (0.17 log units) below it; the range from low to high includes it.
By their numbers in this assay, from the lowest: compounds 3, 4, 2 and 1 (each within the scatter of the next, the first and the last beyond it).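

In this assay, phenyl in place of ethyl on this saturated ring carbon gives a 1.3-fold lower number from compound 2 to compound 4 (0.10 log units; within the scatter), and phenyl in place of hydrogen gives a 1.3-fold lower number from compound 1 to compound 4 (0.11 log units; within the scatter), so a six-membered aromatic ring of carbon only can stand on this carbon without leaving the scatter of either compound. Phenyl in place of cyclopropylmethyl gives a 1.8-fold higher number from compound 3 to compound 4 (0.26 log units; within the scatter), which places compound 4 within the scatter of compound 3 as well, although compound 3 lies beyond the scatter of both compound 1 and compound 2. A larger group at this carbon is therefore not enough on its own to reproduce the separation seen for compound 3, since compound 4, with 6 heavy atoms in phenyl against 2 in ethyl, shows no such separation from compound 1 or compound 2.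

The compounds shown leave open whether an amine, a carboxylic acid or a longer chain on this carbon would move the number beyond the scatter of compound 2, and whether benzyl would fall closer to compound 3 or to compound 1. Nothing available here gives a reason for any of these steps.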